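From acid to longer diethylamide chain

A few compounds are considered here, and "the series" means these few. Any claim that something is new, unique, unknown or untested is made for them only; others in the source may bear on it.

In a functional assay on PC-3 cells (Homo sapiens) for cytotoxicity, read by colorimetric assay and MTT assay (on this read-out higher numbers stand for weaker inhibition and lower numbers for stronger inhibition), compound 1 `CCN(CC)C(=O)Cn1c(=O)c(-c2ccc(OC)cc2)cc2c(OC)cc(OC)cc21` gives 10000 nM. Compound 2 `COc1ccc(-c2cc3c(OC)cc(OC)cc3n(CC(=O)O)c2=O)cc1` gives 10000 nM, level with compound 1. Compound 3 `CCN(CC)C(=O)CCn1c(=O)c(-c2ccc(OC)cc2)cc2c(OC)cc(OC)cc21` differs from compound 2 by (diethylcarbamoyl)methyl in place of carboxy on a saturated chain carbon bound to an aromatic nitrogen, with (diethylcarbamoyl)methyl in place of carboxy on a saturated chain carbon bound to an aromatic nitrogen. Within the data shown here, the only measured step that bears on this is no change at the digits printed from compound 1 to compound 2 (within the scatter), which stayed within the scatter. No change beyond the scatter is therefore expected in this assay. The expected size is no change at the digits printed from compound 2 to compound 3 (within the scatter). For compound 3 the estimate is 10000 nM, with an expected range from 4000 nM to 20000 nM.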

Compound 3, half-maximal inhibitory concentration: 10000 nM
Estimate against measurement, compound 3: no gap at the digits printed; the measured number falls inside the stated range.
By their numbers in this assay, from the lowest: compounds 1, 2 and 3 (each within the scatter of the next).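

In this assay, the side chain now gives two further steps: no change at the digits printed from compound 2 to compound 3 (within the scatter), and no change at the digits printed from compound 1 to compound 3 (within the scatter). At this saturated chain carbon bound to an aromatic nitrogen, therefore, neither (diethylcarbamoyl)methyl in place of carboxy nor (diethylcarbamoyl)methyl in place of diethylcarbamoyl moved the read-out beyond the scatter, which the earlier pair could not show for the longer chain. No evidence is available that bears on this result. On these data alone, whether a longer chain or a morpholine amide in place of the diethylamide would shift the value remains open.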